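Branching the Chain on the Aromatic Nitrogen

The source may hold more compounds than are shown below. What is called first, only, known or untested is meant among the compounds shown, and "the series" means these compounds.

Measured so far, in an assay on membranes from Jurkat cells for displacement of a labelled ligand from Sigma intracellular receptor 2 (Homo sapiens), read by scintillation counting, with a stated time of 1 h; a higher number here means a weaker inhibitor, a lower number a stronger inhibitor:
compound 1 `Cn1nc(CN2CCCC2)nc1-c1ccc(C2CC2)cc1`: 1000 nM
compound 2 `Cn1nc(CN2CCCC2)nc1-c1ccc2ccsc2c1`: > 1000 nM
compound 3 `CCn1nc(CN2CCCC2)nc1-c1ccc(C(C)(C)C)cc1`: 1710 nM

Compound 3 has the higher of the two numbers in this assay, with compound 1 the nearest, and the gap between them sits within the usual scatter. For compound 2 the value is not a number but a limit of the assay, (the limit of > 1000 nM in this assay, at which 1 of the 3 values shown sits).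

Compound 4 `CC(C)n1nc(CN2CCCC2)nc1-c1ccc(C(C)(C)C)cc1` differs from compound 3 in one place: methyl in place of hydrogen on a saturated chain carbon bound to an aromatic nitrogen and a saturated chain carbon. Within the data shown here, no measured pair shows this change, so no step size is known from the data. A small step, if any, is expected in this assay, not beyond the scatter, and compound 4 is estimated at 2000 nM (range 700 nM to 6000 nM), a step of a 1.2-fold higher number from compound 3 to compound 4 (0.07 log units; within the scatter).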

Compound 4, inhibition constant: 1460 nM
Estimate against measurement, compound 4: 1.4-fold (0.14 log units) above; low and high end bracket the measured number.
By their numbers in this assay, from the lowest: compounds 1, 4 and 3 (each within the scatter of the next).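

Among these compounds, changing ethyl to isopropyl gives a 1.2-fold lower number from compound 3 to compound 4 (0.07 log units; within the scatter) in this assay, the only step measured so far between compounds that differ in one place. At this position, then, an added methyl on the saturated chain carbon bound to an aromatic nitrogen leaves the number indistinguishable from that of compound 3. Nothing measured here bears on why this is so.

Going by these compounds, whether a much larger group on that nitrogen, such as benzyl, or a chain carrying an amine or a carboxylic acid would move the number beyond the scatter remains open. Compound 1 and compound 2 carry methyl there but also differ from compound 3 on the other side of the core, so the step from methyl to ethyl cannot be read.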